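Adding a chlorophenyl group to a weakly cytotoxic compound

The source may hold more compounds than are shown below. What is called first, only, known or untested is meant among the compounds shown, and "the series" means these compounds.

- compound 1 `C=CC(=O)N1C(=O)CC(c2ccc(C)cc2)Sc2ccccc21`: 75500 nM
- compound 2 `C=CC(=O)N1C(=O)CCSc2ccccc21`: 581000 nM

In a functional assay on Raji cells (Homo sapiens) for cytotoxicity, read by CCK-8 assay, with a stated time of 24 h (on this read-out lower numbers stand for stronger inhibition and higher numbers for weaker inhibition), compound 2 gives 581000 nM, the highest of the two numbers and so the weaker result. Compound 3 `C=CC(=O)N1C(=O)CC(c2ccccc2Cl)Sc2ccccc21` differs from it by one change: 2-chlorophenyl in place of hydrogen on a saturated ring carbon. In short, 2-chlorophenyl takes the place of hydrogen on a saturated ring carbon, next to the ring sulfur.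

Within the data shown here, only one measured step bears on this change. Replacing 4-methylphenyl with hydrogen on that carbon gave a 7.7-fold higher number from compound 1 to compound 2 (0.89 log units; beyond the scatter). Compound 3 reverses that kind of change, but with a different group, and a single step cannot show how much the group's identity matters. A drop of similar size is therefore expected in this assay. The estimated change is an 8.3-fold lower number from compound 2 to compound 3 (0.92 log units; beyond the scatter). Compound 3 is expected at about 70000 nM, within a range of 22000 nM to 220000 nM.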

Compound 3, half-maximal inhibitory concentration: 50400 nM
Beside the measured number, compound 3's estimate is 1.4-fold (0.14 log units) above it; measured number inside the range.
By their numbers in this assay, from the lowest: compounds 3 and 1 (each within the scatter of the next); then compound 2.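

In this assay a second aromatic group on this saturated ring carbon also gives a clear gain, with a 12-fold lower number from compound 2 to compound 3 (1.06 log units; beyond the scatter) for the 2-chlorophenyl group, so the earlier gain is not unique to 4-methylphenyl. Exchanging one aromatic group for the other gives a 1.5-fold lower number from compound 1 to compound 3 (0.18 log units; within the scatter) and so separates the two no more than repeat measurements would, which means that among these three compounds the clear difference lies between hydrogen and a substituted phenyl ring. No measurement shown here accounts for this difference.

As far as these compounds go, it remains open whether a ring is needed at all, or whether a simple methyl group or a longer alkyl chain on this carbon would do the same. A phenyl ring carrying an amine or a carboxylic acid is also untested among the compounds shown.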